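The source may report more compounds than this note shows. Statements on the series, on what has been measured and on what is new or still open speak of the compounds shown alone.

In an assay (Rattus norvegicus) for inhibition of Fatty-acid amide hydrolase 1 (Homo sapiens) (a higher number here means a weaker inhibitor, a lower number a stronger inhibitor), compound 3 `NC(=O)c1cccc(-c2cnc(C(=O)CCCCCCc3ccccc3)o2)n1` gives 1 nM, the lowest of the three numbers: compound 1 `NC(=O)c1cccc(-c2cnc(C(=O)CCCCCCc3ccccc3)o2)c1` gives 6 nM and compound 2 `Cc1cccc(-c2cnc(C(=O)CCCCCCc3ccccc3)o2)n1` gives 3.3 nM, with steps of a 6.0-fold lower number from compound 1 to compound 3 (0.78 log units; beyond the scatter) and a 3.3-fold lower number from compound 2 to compound 3 (0.52 log units; beyond the scatter), while a 1.8-fold lower number from compound 1 to compound 2 (0.26 log units; within the scatter). Compound 4 `CN1CCN(C(=O)c2cnc(C(=O)CCCCCCc3ccccc3)o2)CC1` carries (4-methylpiperazin-1-yl)carbonyl in place of 6-carbamoylpyridin-2-yl on an aromatic carbon. Among the measured compounds shown here, no measured step removes the six-membered aromatic ring; the two steps that reach compound 3 only exchange groups on it, and both favour the 6-carbamoylpyridin-2-yl group. The change to compound 4 therefore lies outside what the measured steps cover, and a weaker inhibitor is expected, by a step of a 60-fold higher number from compound 3 to compound 4 (1.78 log units; beyond the scatter). Compound 4 is thus estimated at 60 nM, within 10 nM to 400 nM.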

Compound 4, inhibition constant: 80 nM
The estimate for compound 4 lay 1.3-fold (0.12 log units) below the measured number; the range from low to high includes it.
By their numbers in this assay, from the lowest: compound 3; then compounds 2 and 1 (each within the scatter of the next); then compound 4.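

In this assay the aromatic carbon next to the ring oxygen tolerates exchanges on the six-membered aromatic ring far better than that ring's replacement by (4-methylpiperazin-1-yl)carbonyl (an 80-fold higher number from compound 3 to compound 4 (1.90 log units; beyond the scatter)). The loss remains large when measured from the methyl compound, which has no carbamoyl group (a 24-fold higher number from compound 2 to compound 4 (1.38 log units; beyond the scatter)), and from the phenyl compound (a 13-fold higher number from compound 1 to compound 4 (1.12 log units; beyond the scatter)). Nothing available explains its size. As far as these compounds go, compound 4 changes the ring and its link to the core together, so which of these matters stays open. A simple primary carboxamide or an unsubstituted phenyl at this carbon would help separate them.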